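This account rests on a few compounds, and the source may have more. Where it says the series, first, only, none or still open, it means among the compounds named here.

Measured so far:
compound 1 `CCOC(=O)c1ccc(-c2nn(Cc3cccc(Cl)c3)c3ccccc23)cc1` gives 80 nM in a functional assay on cells (Platelet, Homo sapiens) for inhibition; on this read-out lower numbers stand for stronger inhibition and higher numbers for weaker inhibition
compound 2 `CCOC(=O)c1ccc(-c2nn(-c3ccoc3)c3ccccc23)cc1` gives 580 nM in this assay

For the measured compounds named here, of these two numbers, compound 2 holds the higher one, meaning it inhibits less strongly than compound 1; the single measured step, a 7.3-fold higher number from compound 1 to compound 2 (0.86 log units; beyond the scatter), shows the size of that gap. Compound 3 `CCOC(=O)c1ccc(-c2nn(-c3ccccc3)c3ccccc23)cc1` has not yet been measured. It differs from compound 2 by phenyl in place of furan-3-yl on an aromatic nitrogen. Going by the values given here, no measured step swaps exactly these two groups. Among the compounds with values here, the one step available, a 7.3-fold higher number from compound 1 to compound 2 (0.86 log units; beyond the scatter), concerns the same nitrogen but traded 3-chlorobenzyl for furan-3-yl, so it only shows that a change at this nitrogen can move the read-out by a modest amount. A phenyl ring bound directly to the nitrogen resembles parts of both earlier groups, so for compound 3 a step of a 1.9-fold lower number from compound 2 to compound 3 (0.29 log units; within the scatter) in this assay is expected, toward a somewhat lower number. Compound 3 is therefore estimated at 300 nM, with a range from 100 nM to 900 nM.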

Compound 3, half-maximal inhibitory concentration: 2640 nM
Estimate against measurement, compound 3: 8.8-fold (0.94 log units) below; measured number outside the range, above it.
By their numbers in this assay, from the lowest: compound 1; then compound 2; then compound 3.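

Replacing furan-3-yl with phenyl on this aromatic nitrogen gives a 4.6-fold higher number from compound 2 to compound 3 (0.66 log units; beyond the scatter) in this assay, so these two aromatic rings, each attached directly at the same place, are not interchangeable here. Set against 3-chlorobenzyl, phenyl gives a 33-fold higher number from compound 1 to compound 3 (1.52 log units; beyond the scatter) and is the widest gap so far, which puts the three groups in a clear order, with 3-chlorobenzyl giving the lowest number and phenyl the highest. Nothing available explains what lies behind this order.

Still open, as far as these compounds go, is whether compound 1 owes its lower number to the chlorine or to the carbon link between the ring and the nitrogen, a question that a plain benzyl group at this nitrogen would help settle. It is also unclear how the order would hold up with other groups here, such as a pyridine ring or a longer chain ending in an amine.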